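Hydroxymethyl to methyl near the top of the scale

A few compounds are considered here, and "the series" means these few. Any claim that something is new, unique, unknown or untested is made for them only; others in the source may bear on it.

In an ADME assay on CHO cells (Cricetulus griseus) for cytotoxicity, read by MTT assay, with a stated time of 24 h (a lower number here means that less compound is tolerated, a higher number that more compound is tolerated), compound 1 (`CC1Cn2cc([N+](=O)[O-])nc2O1`) stands at a limit, > 500000 nM, and not at a true number. Compound 2 (`CC1Cn2c(nc([N+](=O)[O-])c2Br)O1`) gives 9190 nM. For the measured compounds named here, the one measured step is an at least 54-fold lower number from compound 1 to compound 2 (1.73 log units; beyond the scatter). Compound 3 (`CC1Cn2c(nc([N+](=O)[O-])c2-c2ccc(CO)cc2)O1`) also stands at a limit, > 500000 nM. Much of the series therefore sits at the top of the scale: the limit of > 500000 nM in this assay, at which 2 of the 3 values shown sit.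

Compound 4 (`Cc1ccc(-c2c([N+](=O)[O-])nc3n2CC(C)O3)cc1`) changes one place in compound 3: hydrogen in place of hydroxy on a saturated chain carbon bound to an aromatic carbon. Put simply, hydroxymethyl becomes methyl. Going by the values given here, no measured step covers this change. The bromo step concerns bromo in place of hydrogen on an aromatic carbon, so it shows only that this assay can move far after a single substitution. With compound 3 at > 500000 nM, the expectation is a small move toward a lower number, or none beyond the scatter. The expected step is an at least 1.6-fold lower number from compound 3 to compound 4 (0.22 log units; that floor lies within the scatter). Compound 4 is estimated at 300000 nM, with an expected range from 80000 nM to 500000 nM.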

Compound 4, half-maximal cytotoxic concentration: > 250000 nM
Compound 4 ended at the assay's limit; the forecaster's own chance of this, stated with the estimate: 55%; the middle value is on the limit's open side.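

For the compounds shown here, compound 3 and compound 4 both stand at limits and not at true numbers, so no step between them can be read in this assay. The compounds shown leave open whether going from hydroxymethyl to methyl moves the number at all, and in which direction.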